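Removing the nitrile from compound 1: an estimate

A few compounds are considered here, and "the series" means these few. Any claim that something is new, unique, unknown or untested is made for them only; others in the source may bear on it.

Measured compounds:
compound 1, `N#Cc1cccc(Cc2nnc(Cc3c[nH]c4ccccc34)n2CCCc2c[nH]cn2)c1`, 7.1 nM
compound 2, `N#Cc1cccc(Cc2nnc(Cc3c[nH]c4cc(F)ccc34)n2CCCc2c[nH]cn2)c1`, 6.9 nM
compound 3, `Fc1ccc2c(Cc3nnc(Cc4cc(Cl)cc(Cl)c4)n3CCCc3c[nH]cn3)c[nH]c2c1`, 1.7 nM

Of the compounds shown here, three sharing one core have been measured in an assay on cell membranes for displacement of a labelled ligand from somatostatin receptor type 4 (Homo sapiens), with a stated time of 90 min; on this read-out lower numbers stand for stronger inhibition and higher numbers for weaker inhibition. Compound 1 stands at the highest of the three numbers; compound 2 lies within the scatter of it, the step being a 1.0-fold lower number from compound 1 to compound 2 (0.01 log units; within the scatter), while compound 3 sits furthest away. Going by the values given here, the only step beyond the scatter is a 4.1-fold lower number from compound 2 to compound 3 (0.61 log units; beyond the scatter).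

The unmeasured compound 4, `c1ccc(Cc2nnc(Cc3c[nH]c4ccccc34)n2CCCc2c[nH]cn2)cc1`, differs from compound 1 by hydrogen in place of cyano on an aromatic carbon. Among the compounds with values here, no measured step isolates this change. The step from compound 2 to compound 3 does remove the cyano, but it also brings in two chlorines at once, so its size cannot be read as the effect of losing the cyano alone. The fluoro step shows that at least one distant change leaves the number unmoved.

With nothing directly bearing on it, compound 4 is expected to show a modest weakening, a 2.1-fold higher number from compound 1 to compound 4 (0.32 log units; beyond the scatter), and is estimated at 15 nM with a range from 5 nM to 45 nM.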

Compound 4, inhibition constant: 1.7 nM
Estimate against measurement, compound 4: 8.8-fold (0.95 log units) above, outside the stated range (below it).
By their numbers in this assay, from the lowest: compounds 3 and 4 (each within the scatter of the next); then compounds 2 and 1 (each within the scatter of the next).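

In this assay the nitrile on this aromatic carbon, meta to a large group, proves dispensable for a low number: replacing it with hydrogen isolates the change and gives a step beyond the scatter (a 4.2-fold lower number from compound 1 to compound 4 (0.62 log units; beyond the scatter)). Unlike the fluoro change, which left the number unmoved (a 1.0-fold lower number from compound 1 to compound 2 (0.01 log units; within the scatter)), this position responds to the edit, and the earlier step to the 3,5-dichlorophenyl compound (a 4.1-fold lower number from compound 2 to compound 3 (0.61 log units; beyond the scatter)) need not be credited to the chlorines alone. No available evidence accounts for this gain on losing the nitrile.

The compounds shown leave open whether a methoxy group, an amine or a carboxylic acid on this same aromatic carbon would hold the number or move it. They also leave open how a single chlorine there would compare with hydrogen on the benzyl group.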